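Lengthening the Side Chain of Compound 1

The compounds below may be only part of what the source reports. "The series", "measured", "known", "first", "only" and "open" are said of these compounds alone.

- compound 1 (`COc1ccc(N(C)c2nc(C)nc3ccccc23)cc1C(=O)OCC[Se]C#N`): 951 nM
- compound 2 (`COc1ccc(N(C)c2nc(C)nc3ccccc23)cc1OCC[Se]C#N`): 18 nM
- compound 3 (`COc1ccc(N(C)c2nc(C)nc3ccccc23)cc1OCCN`): 198 nM

In a functional assay on HCT-116 cells (Homo sapiens) for inhibition, read by MTT assay, with a stated time of 48 h (a lower number here means a stronger inhibitor, a higher number a weaker inhibitor), compound 1 gives 951 nM, the highest number of the three, which makes it the weakest inhibitor measured so far. Compound 4 (`COc1ccc(N(C)c2nc(C)nc3ccccc23)cc1C(=O)OCCCCC[Se]C#N`) differs from it in one place: a group of 6 heavy atoms (4 carbon, 1 nitrogen, 1 selenium; no ring) in place of a group of 3 heavy atoms (1 carbon, 1 nitrogen, 1 selenium; no ring), on a saturated chain carbon, two bonds along the chain from an oxygen next to a carbonyl group. Going by the values given here, no measured step makes this change, so the evidence is indirect. Two steps start from compound 1 and alter the same side of the molecule: a 53-fold lower number from compound 1 to compound 2 (1.72 log units; beyond the scatter), and a 4.8-fold lower number from compound 1 to compound 3 (0.68 log units; beyond the scatter). A third step, an 11-fold higher number from compound 2 to compound 3 (1.04 log units; beyond the scatter), also falls beyond the scatter. Together they show that changes in this part of the molecule can move the number considerably, but none of them tests chain length. Compound 1 at 951 nM lies above both relatives, so a lower number is the likelier direction, though this is only an expectation. The expected change is a 2.4-fold lower number from compound 1 to compound 4 (0.38 log units; beyond the scatter). For compound 4 the estimated value is 400 nM, with an expected range from 80 nM to 2000 nM.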

Compound 4, half-maximal inhibitory concentration: 551 nM
Compound 4: the middle estimate sits 1.4-fold (0.14 log units) below what was measured; measured number inside the range.
By their numbers in this assay, from the lowest: compound 2; then compound 3; then compounds 4 and 1 (each within the scatter of the next).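

In this assay, lengthening the chain, with the group of 6 heavy atoms in place of the group of 3 heavy atoms, gives a 1.7-fold lower number from compound 1 to compound 4 (0.24 log units; within the scatter) and so leaves the two compounds indistinguishable. Going by these compounds alone, this is the first direct test of chain length at this position, and over these two lengths the chain alone does not shift the result beyond the scatter, whereas the larger change on the aromatic carbon gave a 53-fold lower number from compound 1 to compound 2 (1.72 log units; beyond the scatter) in the same test. Nothing measured here offers an explanation for this result.

From the compounds shown here alone, whether a still longer chain would behave the same way remains open. So does the effect of an amine at the end of this longer chain, or of the same longer chain joined through the ether oxygen of compound 2 instead of the carbonyl-bearing link.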